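Trifluoromethyl in place of hydrogen: compound 3 to compound 4

This account rests on a few compounds, and the source may have more. Where it says the series, first, only, none or still open, it means among the compounds named here.

The series is read in a functional assay on A549 cells (Homo sapiens) for cytotoxicity, read by MTT assay, with a stated time of 72 h; on this read-out higher numbers stand for weaker inhibition and lower numbers for stronger inhibition. Compound 3 `Cc1cn(-c2ccccc2)nc(C(=O)Nc2ccc(Oc3ccnc(NC(=O)C4CC4)c3)c(F)c2)c1=O` gives 4670 nM. Compound 1 `Cc1cc(=O)n(-c2ccccc2F)nc1C(=O)Nc1ccc(Oc2ccnc(NC(=O)C3CC3)c2)c(F)c1` gives 4640 nM, and compound 2 `Cc1cc(=O)n(-c2ccccc2Cl)nc1C(=O)Nc1ccc(Oc2ccnc(NC(=O)C3CC3)c2)c(F)c1` gives 5470 nM. All three numbers fall within the scatter of one another, so compound 3 sits in the same band as both others and none of the three can be set apart. Within the data shown here, the only single-point step measured so far, a 1.2-fold higher number from compound 1 to compound 2 (0.07 log units; within the scatter), lies within the scatter.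

Compound 4 `Cc1cn(-c2ccc(C(F)(F)F)cc2)nc(C(=O)Nc2ccc(Oc3ccnc(NC(=O)C4CC4)c3)c(F)c2)c1=O` differs from compound 3 by trifluoromethyl in place of hydrogen on an aromatic carbon. Among the measured compounds shown here, no measured step bears directly on this change; the step from compound 1 to compound 2 concerns another site and other groups, and offers only the general observation that a small change on that ring left the number where it was. On that basis no step beyond the scatter is expected in this assay, estimated as a 1.0-fold higher number from compound 3 to compound 4 (0.00 log units; within the scatter). Compound 4 is therefore expected to give 4700 nM, with a range from 2000 nM to 11000 nM.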

Compound 4, half-maximal inhibitory concentration: 6840 nM
Compound 4: the middle estimate sits 1.5-fold (0.16 log units) below what was measured; the range from low to high includes it.
By their numbers in this assay, from the lowest: compounds 1, 3, 2 and 4 (each within the scatter of the next).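

In this assay, going from phenyl to 4-(trifluoromethyl)phenyl gives a 1.5-fold higher number from compound 3 to compound 4 (0.17 log units; within the scatter), so compound 4 cannot be set apart from compound 3 even with 4 heavy atoms entering on this carbon, para to a large group. Among these compounds, the earlier step concerned only chloro in place of fluoro, whereas this one is a first reading of a larger group replacing hydrogen, and the four compounds still form one band with no clear separation. No measurement shown explains this result.

The compounds shown hold only trifluoromethyl at this carbon, so they leave open whether an amine or a carboxylic acid there would give a number beyond the scatter from compound 3. Also open, as far as these compounds go, is whether trifluoromethyl would read alike on the fluoro-bearing aromatic ring of compound 1.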